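The compounds below may be only part of what the source reports. "The series", "measured", "known", "first", "only" and "open" are said of these compounds alone.

In a functional assay on HL-60 cells (Homo sapiens) for inhibition, read by MTT assay, with a stated time of 48 h, tested at 10 uM (a higher number here means more inhibition of growth at the concentration tested, a lower number less inhibition of growth), compound 1 `Cc1cc(=O)c2c(O)cc(OCc3ccccc3)c([C@H]3CCN(C)C[C@H]3O)c2o1` gives 24% and compound 2 `COc1ccc(COc2cc(O)c3c(=O)cc(C)oc3c2[C@H]2CCN(C)C[C@H]2O)cc1` gives 23%, so the two stand level within the scatter. Compound 3 `Cc1cc(=O)c2c(O)cc(OCc3ccc(Br)cc3)c([C@H]3CCN(C)C[C@H]3O)c2o1` is still unmeasured and differs from compound 1 by one change: bromo in place of hydrogen on an aromatic carbon. Among the measured compounds shown here, only one measured step bears on this, methoxy in place of hydrogen on an aromatic carbon, and it is a number 1 percentage points lower from compound 1 to compound 2 (within the scatter). One small step is thin evidence, but no change beyond the scatter is expected in this assay. The expected step is a number 1 percentage points higher from compound 1 to compound 3 (within the scatter). The estimated value for compound 3 is 25%, within an expected range of 12% to 40%.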

Compound 3, percent growth inhibition at one concentration: 27%
Estimate against measurement, compound 3: 2 percentage points below; low and high end bracket the measured number.
By their numbers in this assay, from the lowest: compounds 2, 1 and 3 (each within the scatter of the next).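

Bromo in place of hydrogen gives a number 3 percentage points higher from compound 1 to compound 3 (within the scatter) in this assay and bromo in place of methoxy gives a number 4 percentage points higher from compound 2 to compound 3 (within the scatter) on the same aromatic carbon. With a second, different group in this place, hydrogen, methoxy and bromo all stand level, so this position para to a large group has so far taken either substituent without a change beyond the scatter. Nothing measured here explains why the readings stand level. From the compounds shown here alone, whether an amine or a carboxylic acid in this place would shift the reading stays open. So does the effect of a longer chain between the ring and the core.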